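Halophenyl exchange on the fused core of compound 2

The compounds below may be only part of what the source reports. "The series", "measured", "known", "first", "only" and "open" are said of these compounds alone.

Among the compounds with values here, compound 2 `CC(C)Cc1ccc(C(C)c2nnc3sc(-c4ccc(Br)cc4)nn23)cc1` holds the higher of the two numbers so far: in a functional assay on the whole organism (strain Wistar albino) for inhibition, with Rattus norvegicus as the target, read by paw edema, with stated times of 30 min and 2 h, at a dose of 20 mg/kg by the oral route (a lower number here means less inhibition, a higher number more inhibition at the dose given (going by the name of the read-out)), compound 2 gives 64%, while compound 1 `CCCc1nn2c(C(C)c3ccc(CC(C)C)cc3)nnc2s1` gives 28% in this assay. Within the data shown here, the one measured step, a number 36 percentage points higher from compound 1 to compound 2 (beyond the scatter), puts 4-bromophenyl in place of propyl on an aromatic carbon. Compound 3 `CC(C)Cc1ccc(C(C)c2nnc3sc(-c4ccccc4Cl)nn23)cc1` changes compound 2 by 2-chlorophenyl in place of 4-bromophenyl on an aromatic carbon. Among the measured compounds shown here, no measured step exchanges one halophenyl for another, so the step from compound 1 to compound 2 does not carry over directly. Compound 3 is therefore expected to stay close to compound 2, with a number 6 percentage points lower from compound 2 to compound 3 (within the scatter) not beyond the scatter. The estimate for compound 3 in this assay is 58%, ranging 40% to 72%.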

Compound 3, a percentage reported as inhibition, in the whole organism at one dose (the size of the read-out at that dose, not a potency): 59%
Compound 3: the middle estimate sits 1 percentage points below what was measured; the range from low to high includes it.
By their numbers in this assay, from the lowest: compound 1; then compounds 3 and 2 (each within the scatter of the next).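

In this assay, the exchange on this aromatic carbon gives a number 5 percentage points lower from compound 2 to compound 3 (within the scatter), so 2-chlorophenyl and 4-bromophenyl cannot be told apart here. With a number 31 percentage points higher from compound 1 to compound 3 (beyond the scatter), the rise over propyl seen with 4-bromophenyl also holds for a second halophenyl group. No available data bear on the reason for either result.

Halogen and ring position change together in this exchange, so the compounds shown leave their separate contributions open. Also open, going by these compounds, is how a plain phenyl or an aminophenyl group would compare on this carbon.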